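This account rests on a few compounds, and the source may have more. Where it says the series, first, only, none or still open, it means among the compounds named here.

Measured so far: compound 1 `COC(=O)Nc1nc2ccc(NC(=O)c3c(Cl)cccc3Cl)cc2s1` and compound 2 `O=C(Nc1nc2ccc(NC(=O)c3c(Cl)cccc3Cl)cc2s1)Oc1ccccc1`.

In a functional assay on WI-38 VA13 cells (Homo sapiens) for cytotoxicity (a lower number here means that less compound is needed, a higher number that more compound is needed for the effect), compound 1 gives 0.0095 ug/mL, while compound 2 gives 1.1 ug/mL, the highest of the two numbers. Among the measured compounds shown here, the one step so far, a 120-fold higher number from compound 1 to compound 2 (2.06 log units; beyond the scatter), changed the same substituent that is changed now. Compound 3 `COc1ccc(Nc2nc3ccc(NC(=O)c4c(Cl)cccc4Cl)cc3s2)cc1` carries 4-methoxyphenyl in place of phenoxycarbonyl on a nitrogen on an aromatic ring. That single earlier step shows the substituent on this nitrogen matters greatly, but it does not show which way a 4-methoxyphenyl group will move the number. Compound 3 is therefore expected to stay near compound 2, with an expected step of a 1.1-fold lower number from compound 2 to compound 3 (0.04 log units; within the scatter), and an estimated value of 1 ug/mL (range 0.1 ug/mL to 10 ug/mL).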

Compound 3, half-maximal effective concentration: 0.87 ug/mL
Estimate against measurement, compound 3: 1.1-fold (0.06 log units) above; the range from low to high includes it.
By their numbers in this assay, from the lowest: compound 1; then compounds 3 and 2 (each within the scatter of the next).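

In this assay, a 1.3-fold lower number from compound 2 to compound 3 (0.10 log units; within the scatter) shows that 4-methoxyphenyl and phenoxycarbonyl on this nitrogen cannot be told apart, although only phenoxycarbonyl contains a carbonyl. With a 92-fold higher number from compound 1 to compound 3 (1.96 log units; beyond the scatter) beyond the scatter, methoxycarbonyl alone stands apart among these three groups, giving the lowest number. No available evidence bears on this result. The compounds shown leave open whether an ethoxycarbonyl group, an acetyl group or a free amine on this nitrogen would fall near compound 1 or near compound 2 and compound 3.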